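Diethylamino chalcone ether: expected lipophilicity from neighbours

The compounds below may be only part of what the source reports. "The series", "measured", "known", "first", "only" and "open" are said of these compounds alone.

Measured so far:
Compound 1 `CCCCN(CCCC)CCCOc1ccc(C(=O)/C=C/c2ccccc2)cc1`: 2.06
Compound 2 `CN(C)CCCCOc1ccc(C(=O)/C=C/c2ccccc2)cc1`: 1.64

In a physicochemical assay for lipophilicity, using the shake flask method, measured as octanol-water partition, at pH 7.4 (on this read-out lower numbers stand for lower lipophilicity and higher numbers for higher lipophilicity), compound 2 stands lowest of the two numbers; its nearest neighbour is compound 1, whose value lies above it by the step of a number 0.42 log units lower from compound 1 to compound 2 (beyond the scatter). Compound 3 `CCN(CC)CCCCOc1ccc(C(=O)/C=C/c2ccccc2)cc1` carries the change (diethylamino in place of dimethylamino on a saturated chain carbon, four bonds along the chain from an oxygen on an aromatic ring). Among the compounds with values here, only that one step bears on it: it combined a larger amine with a shorter chain, and went down modestly. Adding two carbons at the amine should therefore move this assay up, by an amount estimated as a number 0.31 log units higher from compound 2 to compound 3 (beyond the scatter). Compound 3 is expected at 1.95, within 1.55 to 2.35.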

Compound 3, partition coefficient: 1.74
Beside the measured number, compound 3's estimate is 0.21 log units above it; measured number inside the range.
By their numbers in this assay, from the lowest: compounds 2 and 3 (each within the scatter of the next); then compound 1.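

In this assay diethylamino in place of dimethylamino, four bonds along the chain from an oxygen on an aromatic ring, gives a number 0.10 log units higher from compound 2 to compound 3 (within the scatter) and so adds two carbons at the amine without a readable shift. (Diethylamino)methyl in place of dibutylamino gives a number 0.32 log units lower from compound 1 to compound 3 (beyond the scatter) and stays beyond the scatter, so among these three only compound 1 stands apart. No evidence is available to account for this result. Still open, from the compounds shown here alone, is whether dibutylamino on this longer chain, or a piperidine in place of diethylamino, would stand apart from compound 2 and compound 3.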